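Swapping the thiadiazole ester for a pyridine ester

The source may report more compounds than this note shows. Statements on the series, on what has been measured and on what is new or still open speak of the compounds shown alone.

Measured compounds:
- compound 1 `CC(=O)Oc1ccccc1C(=O)O[C@H]1CO[C@H]2[C@@H]1OC[C@H]2OC(=O)c1snnc1C`: 0.0065 h
- compound 2 `CC(=O)Oc1ccccc1C(=O)O[C@H]1CO[C@H]2[C@@H]1OC[C@H]2OC(=O)c1cccc(O)c1`: 0.015 h

In an ADME assay on a cell-free system (plasma, Homo sapiens) for metabolic stability, with Plasma (Rattus norvegicus) as the target, read by HPLC, at pH 7.4 (on this read-out higher numbers stand for a longer-lived compound and lower numbers for a shorter-lived compound), compound 1 gives 0.0065 h, the lowest of the two numbers; its nearest neighbour is compound 2, which gives 0.015 h. For the measured compounds named here, the only measured step is a 2.3-fold higher number from compound 1 to compound 2 (0.36 log units; beyond the scatter), a modest gain obtained by changing the group on the carbonyl carbon. Compound 3 `CC(=O)Oc1ccccc1C(=O)O[C@H]1CO[C@H]2[C@@H]1OC[C@H]2OC(=O)c1cccnc1` has not yet been measured; it differs from compound 1 as follows: pyridin-3-yl in place of 4-methyl-1,2,3-thiadiazol-5-yl on a carbonyl carbon. Going by the values given here, this change touches the same carbonyl carbon as the step from compound 1 to compound 2, so that step is the only guide, and it points toward a modest rise rather than none. Compound 3 is therefore expected to show a 1.8-fold higher number from compound 1 to compound 3 (0.27 log units; within the scatter) in this assay. The estimated value for compound 3 is 0.012 h, with a likely range from 0.005 h to 0.03 h.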

Compound 3, half-life: 0.00617 h
The estimate for compound 3 lay 1.9-fold (0.29 log units) above the measured number; the measured number falls inside the stated range.
By their numbers in this assay, from the lowest: compounds 3 and 1 (each within the scatter of the next); then compound 2.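

In this assay, replacing 4-methyl-1,2,3-thiadiazol-5-yl with pyridin-3-yl on this carbonyl carbon leaves the read-out within the usual scatter, with a 1.1-fold lower number from compound 1 to compound 3 (0.02 log units; within the scatter), so this position does not respond to every change of group. For the compounds shown here, the other comparison gives a 2.4-fold lower number from compound 2 to compound 3 (0.39 log units; beyond the scatter), which means that a six-membered aromatic ring at this place is not enough on its own to reach the number of compound 2, and 3-hydroxyphenyl is the only one of the three groups that stands apart. The compounds shown offer no measurement that explains this difference.

A plain phenyl group on the same carbonyl carbon would help to show whether the hydroxyl of 3-hydroxyphenyl goes with the higher number of compound 2. On these data alone, whether an amine or a carboxylic acid on that phenyl ring would give a similar number also remains open.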